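This account rests on a few compounds, and the source may have more. Where it says the series, first, only, none or still open, it means among the compounds named here.

Compound 1 `Cc1ccccc1Oc1cccc(COc2ccccc2CCC(=O)OCCCOP(=O)(O)OC[C@H](N)C(=O)O)c1`: in an assay on cells for activation of probable G-protein coupled receptor 34 (Mus musculus), with a stated time of 1 h (a higher number here means a larger maximal response, a lower number a smaller maximal response), compound 1 gives 0.28.
Compound 2 `N[C@@H](COP(=O)(O)OCCCOC(=O)CCc1ccccc1OCc1cccc(Oc2ccccc2Cl)c1)C(=O)O`: in this assay compound 2 gives 0.069.
Compound 3 `N[C@@H](COP(=O)(O)OCCCOC(=O)CCc1ccccc1OCc1cccc(Oc2ccc(Cl)cc2)c1)C(=O)O`: in this assay compound 3 gives 0.76.

Compound 3 stands highest of the three measured compounds: the steps a number 0.48 higher from compound 1 to compound 3 (beyond the scatter) and a number 0.69 higher from compound 2 to compound 3 (beyond the scatter) are both beyond the scatter, while a number 0.21 lower from compound 1 to compound 2 (beyond the scatter) is modest. Compound 4 `N[C@@H](COP(=O)(O)OCCCOC(=O)CCc1ccccc1OCc1cccc(Oc2ccc(I)cc2)c1)C(=O)O` differs from compound 3 by iodo in place of chloro on an aromatic carbon. Going by the values given here, no measured step exchanges one halogen for another at the same place; the measured steps concern which group sits on the oxygen on an aromatic ring, and those were large. Compound 4 is therefore expected to stay near compound 3, the step a number 0.060 lower from compound 3 to compound 4 (within the scatter) being expected to fall within the scatter. Compound 4 is estimated at 0.7, in the range 0.45 to 0.9.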

Compound 4, intrinsic activity: the largest response reached, as a fraction of the reference agonist's: 0.82
Beside the measured number, compound 4's estimate is 0.12 below it; measured number inside the range.
By their numbers in this assay, from the lowest: compound 2; then compound 1; then compounds 3 and 4 (each within the scatter of the next).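

In this assay, iodo in place of chloro on the aromatic carbon gave a number 0.060 higher from compound 3 to compound 4 (within the scatter) and so separates neither halogen from the other at this place. The high maximal response is therefore not confined to the 4-chlorophenyl group: the 4-iodophenyl group also stands clear of the other groups on that oxygen, with a number 0.75 higher from compound 2 to compound 4 (beyond the scatter) and a number 0.54 higher from compound 1 to compound 4 (beyond the scatter) in the same read-out. Nothing available explains this result. The compounds shown leave open how a 4-fluorophenyl, 4-methoxyphenyl or 4-aminophenyl group would behave at this place.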